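From an amide chain to a carboxylic acid

The compounds below may be only part of what the source reports. "The series", "measured", "known", "first", "only" and "open" are said of these compounds alone.

For the measured compounds named here, compound 2 `CCCCC(Nc1c(C#N)c(-c2ccc(-c3ccccc3OCC)cc2)nc2cnccc12)C(N)=O` gives 3.6 in a physicochemical assay for lipophilicity, read by HPLC, at pH 7.5 (on this read-out higher numbers stand for higher lipophilicity and lower numbers for lower lipophilicity), the higher of the two numbers measured so far. Compound 1 `CCOc1ccccc1-c1ccc(-c2nc(NC(C)C(=O)O)c3ccncc3n2)cc1`, which also carries a carboxylic acid, gives 2.1 in this assay, a gap beyond the scatter. Compound 3 `CCOc1ccccc1-c1ccc(-c2nc3cnccc3c(N[C@H](CC)C(=O)O)c2C#N)cc1` has not been measured; it differs from compound 2 by 1-carboxypropyl in place of 1-carbamoylpentyl on a nitrogen on an aromatic ring. Because compound 1 gives 2.1 with its acid, compound 3 is expected to fall well below compound 2, the step of a number 1.30 log units lower from compound 2 to compound 3 (beyond the scatter) being a decrease beyond the scatter. Compound 3 is therefore estimated at 2.3, within 1.6 to 3.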

Compound 3, distribution coefficient: 2.1
The estimate for compound 3 lay 0.20 log units above the measured number; measured number inside the range.
By their numbers in this assay, from the lowest: compounds 1 and 3 (each within the scatter of the next); then compound 2.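

On the shared core, 1-carboxypropyl in place of 1-carbamoylpentyl on a nitrogen on an aromatic ring gives a number 1.50 log units lower from compound 2 to compound 3 (beyond the scatter) in this assay. This is the first step shown at this position, and it shows that the read-out there responds strongly to this change. No measurement shown accounts for the step.

On these data alone, the change alters both the end group and the chain, so how the step divides between them stays open. A 1-carboxypentyl or 1-carbamoylpropyl group at this position would separate the two.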